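Ethoxy in place of naphthalen-2-yl on a carbonyl carbon

The compounds below may be only part of what the source reports. "The series", "measured", "known", "first", "only" and "open" are said of these compounds alone.

In a functional assay on PC-3 cells (Homo sapiens) for inhibition, read by MTT assay, with a stated time of 48 h (on this read-out lower numbers stand for stronger inhibition and higher numbers for weaker inhibition), compound 1 (`COc1ccc(-n2c(SCc3ccccc3)nnc2-c2cc(OC)c(OC)c(OC)c2)cc1`) gives 34100 nM. Compound 2 (`COc1ccc(-n2c(SCC(=O)c3ccc(OC)c(O)c3)nnc2-c2cc(OC)c(OC)c(OC)c2)cc1`) gives > 60000 nM, which is a limit. Compound 3 (`COc1ccc(-n2c(SCC(=O)c3ccc4ccccc4c3)nnc2-c2cc(OC)c(OC)c(OC)c2)cc1`) gives > 60000 nM, also a limit, and so stands at the limit of > 60000 nM in this assay, at which 2 of the 3 values shown sit. Compound 4 (`CCOC(=O)CSc1nnc(-c2cc(OC)c(OC)c(OC)c2)n1-c1ccc(OC)cc1`) differs from it by ethoxy in place of naphthalen-2-yl on a carbonyl carbon. Among the compounds with values here, at that carbon the only measured change is a step that the two limits leave unreadable from compound 2 to compound 3. Further out, the chain shows an at least 1.7-fold higher number from compound 1 to compound 2 (0.24 log units; that floor lies within the scatter) and an at least 1.7-fold higher number from compound 1 to compound 3 (0.24 log units; that floor lies within the scatter). None of these gives a readable size, so no step beyond the scatter is expected in this assay, though any movement would be toward a lower number. The estimated step is an at least 1.3-fold lower number from compound 3 to compound 4 (0.12 log units; that floor lies within the scatter). For compound 4 the expected value is 45000 nM, with an estimated range of 18000 nM to 100000 nM.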

Compound 4, half-maximal inhibitory concentration: > 60000 nM
Compound 4: only a limit was reported; the forecaster's own chance of this, stated with the estimate: 45%; middle value at least 1.3-fold (0.12 log units) away from the limit.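

Compound 4 gives > 60000 nM in this assay, which is a limit, and the steps from compound 2 and compound 3 to it cannot be read. Set against phenyl on the saturated chain carbon bound to a sulfur, ethoxycarbonyl gives an at least 1.7-fold higher number from compound 1 to compound 4 (0.24 log units; that floor lies within the scatter). On this carbonyl carbon, ethoxy, which has no ring, therefore ends where the two aromatic groups ended: the limit of > 60000 nM in this assay, at which 3 of the 4 values shown sit.

Going by these compounds, whether a carboxylic acid, an amine or a longer chain at this position would give a readable value remains open. So does how far compound 2, compound 3 and compound 4 truly lie from compound 1.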